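Replacing the nonyl chain of compound 2

The source may hold more compounds than are shown below. What is called first, only, known or untested is meant among the compounds shown, and "the series" means these compounds.

Measured in a functional assay on cells (T-cell line, Homo sapiens) for inhibition; on this read-out lower numbers stand for stronger inhibition and higher numbers for weaker inhibition:
- compound 1 `COc1cccc(CCCN2CCC(COC(c3ccccc3)c3ccccc3)CC2)c1`: 1500 nM
- compound 2 `CCCCCCCCCCN1CCC(COC(c2ccccc2)c2ccccc2)CC1`: 2600 nM

Among the measured compounds shown here, compound 2, at 2600 nM, stands within the scatter of compound 1, the only other measured compound. For the measured compounds named here, the one measured step, a 1.7-fold higher number from compound 1 to compound 2 (0.24 log units; within the scatter), put heptyl in place of 3-methoxyphenyl on a saturated chain carbon. Compound 3 `c1ccc(C(OCC2CCN(CC3CCc4ccccc4C3)CC2)c2ccccc2)cc1` also changes what the amine nitrogen in a ring carries: 1,2,3,4-tetrahydronaphthalen-2-yl in place of nonyl on a saturated chain carbon bound to an amine nitrogen in a ring, 1,2,3,4-tetrahydronaphthalen-2-yl in place of nonyl. That single step stayed within the scatter, so no shift beyond the scatter is expected in this assay. The expected step is a 1.4-fold lower number from compound 2 to compound 3 (0.16 log units; within the scatter). Compound 3 is estimated at 1800 nM, with an expected range of 700 nM to 4500 nM.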

Compound 3, half-maximal inhibitory concentration: 5600 nM
Compound 3: middle estimate off by 3.1-fold (0.49 log units), on the low side; measured number above the stated range.
By their numbers in this assay, from the lowest: compounds 1 and 2 (each within the scatter of the next); then compound 3.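

In this assay, the group on the amine nitrogen in a ring now proves able to move the number beyond the scatter: 1,2,3,4-tetrahydronaphthalen-2-yl in place of nonyl gives a 2.2-fold higher number from compound 2 to compound 3 (0.33 log units; beyond the scatter). Set against the 2-(3-methoxyphenyl)ethyl group, the same entering group gives a larger but still modest step, a 3.7-fold higher number from compound 1 to compound 3 (0.57 log units; beyond the scatter), so neither open-chain group shown is matched by this fused bicyclic group. Nothing available accounts for this shift.

The compounds shown leave open whether a longer chain than nonyl, or a chain carrying an amine or a carboxylic acid, would move the number in either direction.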